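Methoxy removal on the pyrazole aryl of compound 1

The compounds below may be only part of what the source reports. "The series", "measured", "known", "first", "only" and "open" are said of these compounds alone.

Three analogues of one chalcone-pyrazole core have been run in a functional assay on SK-MEL-2 cells (Homo sapiens) for cytotoxicity, read by sulforhodamine B assay, with a stated time of 48 h, tested at 0.1 uM; on this read-out lower numbers stand for a stronger effect and higher numbers for a weaker effect at the one concentration tested. Compound 1 `COc1cc(-c2cc(/C=C/C(=O)c3ccc(N)cc3)[nH]n2)cc(OC)c1OC` gives 111% there, the highest of the three numbers. Compound 2 `COc1ccc(C(=O)/C=C/c2cc(-c3cc(OC)c(OC)c(OC)c3)n[nH]2)cc1OC` gives 91% in this assay, and compound 3 `COc1ccc(C(=O)/C=C/c2cc(-c3cc(OC)c(OC)c(OC)c3)n[nH]2)cc1` gives 90%. The step of a number 20 percentage points lower from compound 1 to compound 2 (beyond the scatter) and the step of a number 21 percentage points lower from compound 1 to compound 3 (beyond the scatter) both leave the scatter, while the step of a number 1 percentage points lower from compound 2 to compound 3 (within the scatter) stays inside it. The change behind that last step is hydrogen in place of methoxy on an aromatic carbon.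

Compound 4 `COc1ccc(-c2cc(/C=C/C(=O)c3ccc(N)cc3)[nH]n2)cc1OC` is not yet measured. It differs from compound 1 by hydrogen in place of methoxy on an aromatic carbon. The two cores on which the change is made differ by 4-aminophenyl in place of 3,4-dimethoxyphenyl on a carbonyl carbon. The place of the change is not identical either: in compound 1 the leaving methoxy is also meta to a second methoxy group, whereas in compound 2 it is not, so this is the same kind of change rather than the same change.

Going by the values given here, since the one measured step of this kind, a number 1 percentage points lower from compound 2 to compound 3 (within the scatter), stays inside the scatter, the expectation for compound 4 in this assay is a step of about a number 3 percentage points lower from compound 1 to compound 4 (within the scatter), resting on that single pair and on compound 1 standing at 111%. The estimate for compound 4 is therefore 108%, with a range from 92% to 122%; the differing cores and the differing surroundings of the place widen that range.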

Compound 4, a percentage reported as activity, at one concentration (the size of the read-out at that concentration, not a potency): 109%
Beside the measured number, compound 4's estimate is 1 percentage points below it; low and high end bracket the measured number.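

In this assay, hydrogen in place of methoxy on an aromatic carbon gives a number 2 percentage points lower from compound 1 to compound 4 (within the scatter), so on the core of compound 1 this change leaves the read-out within the usual scatter of repeated measurements. Set beside the same kind of change on the other core, the two steps do not differ, and in this series the change carries from one core to the other as a step that stays within the scatter: the same change on two cores in this assay, a number 1 percentage points lower (within the scatter) from compound 2 to compound 3 and a number 2 percentage points lower (within the scatter) from compound 1 to compound 4, 1 percentage points apart, within the scatter of two such steps This does not show that the methoxy group is without effect in general: the comparison rests on two pairs and one tested concentration, the leaving methoxy has different surroundings on the two cores, and neither pair shows how the change behaves on a core where the read-out stands much lower.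

Still open, going by these compounds, is what a different group on that aromatic carbon would do, such as a hydroxyl group, a fluorine atom or a longer chain such as ethoxy. Also open, on these data alone, is whether removing a further methoxy group from the same ring would leave the read-out in this assay as unmoved as removing this one did.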